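The compounds below may be only part of what the source reports. "The series", "measured", "known", "first", "only" and "open" are said of these compounds alone.

Measured compounds:
compound 1 `COc1cc2cc(Oc3ccc(NC(=O)Nc4ccccc4)cc3)c(C)nc2cc1OC` — 70.7%
compound 2 `COc1cc2cc(Oc3ccc(NC(=O)Nc4cccc(C(F)(F)F)c4)cc3)c(C)nc2cc1OC` — 17.2%

In a functional assay on SN12C cells (Homo sapiens) for inhibition, read by sulforhodamine B assay, with a stated time of 48 h, tested at 10 uM (on this read-out higher numbers stand for a weaker effect at the one concentration tested and lower numbers for a stronger effect), compound 1 gives 70.7%, while compound 2 gives 17.2%. Compound 2 therefore stands at the lowest of the two numbers, the nearest neighbour being compound 1, separated by the step of a number 53.5 percentage points lower from compound 1 to compound 2 (beyond the scatter).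

Compound 3 `COc1cc2cc(Oc3ccc(NC(=O)Nc4ccc(Cl)c(Cl)c4)cc3)c(C)nc2cc1OC` differs from compound 2 in one place: 3,4-dichlorophenyl in place of 3-(trifluoromethyl)phenyl on an amide-type nitrogen. Among the measured compounds shown here, the only measured step that bears on this is the one from compound 1 to compound 2, which put a substituent onto the otherwise bare phenyl of the urea and moved the number in this assay strongly downward. Compound 3 keeps a substituted phenyl at the same nitrogen, so no step beyond the scatter is expected from compound 2 to compound 3 in this assay; the expected step is a number 4.8 percentage points higher from compound 2 to compound 3 (within the scatter). Compound 3 is thus estimated at 22%, with a range from 6% to 48%.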

Compound 3, a percentage reported as activity, at one concentration (the size of the read-out at that concentration, not a potency): 22.1%
Beside the measured number, compound 3's estimate is 0.1 percentage points below it, and the stated range covers the measured number.
By their numbers in this assay, from the lowest: compounds 2 and 3 (each within the scatter of the next); then compound 1.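

In this assay, 3,4-dichlorophenyl in place of 3-(trifluoromethyl)phenyl on the amide-type nitrogen gives a number 4.9 percentage points higher from compound 2 to compound 3 (within the scatter), so this position accepts a second substituted phenyl without a change beyond the scatter. Set against the bare phenyl, the same group gives a number 48.6 percentage points lower from compound 1 to compound 3 (beyond the scatter), which shows that the large step at this nitrogen is not confined to trifluoromethyl: it appears with both the fluorine-bearing and the chlorine-bearing group. No measured evidence at hand accounts for this result.

Going by these compounds, whether a phenyl carrying a methoxy group or an amine would read like compound 2 and compound 3 or like compound 1 remains open. Also open, on these data alone, is what a single chlorine on the phenyl would do, or a cyclohexyl ring in place of the phenyl at this nitrogen.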